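The compounds below may be only part of what the source reports. "The series", "measured", "known", "first", "only" and "open" are said of these compounds alone.

Measured compounds:
compound 1 `Cc1ccc(OCC(=O)NNC(=O)c2cc3ccccc3oc2=O)c(C(=O)c2ccccc2Cl)c1` gives 45200 nM in a functional assay on Ehrlich cells (Mus musculus) for cytotoxicity, read by MTT assay, with a stated time of 48 h; a higher number here means a weaker inhibitor, a lower number a stronger inhibitor
compound 2 `Cc1ccc(OCC(=O)NNC(=O)c2cc3ccccc3oc2=O)c(C(=O)c2ccc(Cl)cc2)c1` gives 56600 nM in this assay
compound 3 `Cc1ccc(OCC(=O)NNC(=O)c2cc3ccccc3oc2=O)c(C(=O)c2ccc(Br)cc2)c1` gives 87300 nM in this assay

Compound 3 has the highest of the three numbers in this assay, yet its steps to the others, a 1.9-fold higher number from compound 1 to compound 3 (0.29 log units; within the scatter) and a 1.5-fold higher number from compound 2 to compound 3 (0.19 log units; within the scatter), both sit within the scatter, so no ordering among the three can be read from them. Compound 4 `Cc1ccc(OCC(=O)NNC(=O)c2cc3ccccc3oc2=O)c(C(=O)c2ccc(F)cc2)c1` differs from compound 3 in one place: fluoro in place of bromo on an aromatic carbon. The step that bears most directly on this change is the halogen exchange a 1.5-fold higher number from compound 2 to compound 3 (0.19 log units; within the scatter), which stayed within the scatter; the step of a 1.3-fold higher number from compound 1 to compound 2 (0.10 log units; within the scatter) concerns a different change and adds little. Compound 4 is therefore expected to show no step beyond the scatter, a 1.2-fold lower number from compound 3 to compound 4 (0.10 log units; within the scatter). The estimate for compound 4 in this assay is 70000 nM, with a range from 30000 nM to 160000 nM.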

Compound 4, half-maximal inhibitory concentration: 39700 nM
Beside the measured number, compound 4's estimate is 1.8-fold (0.25 log units) above it; low and high end bracket the measured number.
By their numbers in this assay, from the lowest: compounds 4, 1, 2 and 3 (each within the scatter of the next, the first and the last beyond it).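

In this assay, among these compounds, the halogen exchange at this position now produces a step that clears the scatter: fluoro in place of bromo gives a 2.2-fold lower number from compound 3 to compound 4 (0.34 log units; beyond the scatter), a modest change that no earlier pair showed. The other two steps stay within the scatter, with fluoro in place of chloro giving a 1.4-fold lower number from compound 2 to compound 4 (0.15 log units; within the scatter) and 4-fluorophenyl in place of 2-chlorophenyl giving a 1.1-fold lower number from compound 1 to compound 4 (0.06 log units; within the scatter), so only the two ends of the halogen series separate. Nothing available explains this difference. The compounds shown leave open how an amine, a methoxy group or a carboxylic acid would behave at this position, since all four carry a halogen on this ring.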